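The compounds below may be only part of what the source reports. "The series", "measured", "known", "first", "only" and "open" are said of these compounds alone.

Of the compounds shown here, three sharing one core have been measured in a functional assay on A-431 cells (Homo sapiens) for antiproliferative activity, read by sulforhodamine B assay, with a stated time of 72 h; a higher number here means a weaker inhibitor, a lower number a stronger inhibitor. Compound 1 `CN(C)CCNC(=O)Nc1cc2c(Nc3ccc(F)c(Cl)c3)ncnc2cc1O[C@H]1CCOC1` gives 806 nM in this assay, the lowest of the three numbers and therefore the strongest inhibitor among them. Compound 2 `COCCCNC(=O)Nc1cc2c(Nc3ccc(F)c(Cl)c3)ncnc2cc1O[C@H]1CCOC1` gives 4100 nM, and compound 3 `O=C(Nc1cc2c(Nc3ccc(F)c(Cl)c3)ncnc2cc1O[C@H]1CCOC1)N1CCC(F)CC1` gives 3040 nM. Compound 2 and compound 3 sit close to each other: a 1.3-fold lower number from compound 2 to compound 3 (0.13 log units; within the scatter).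

Compound 4 `C#CCNC(=O)Nc1cc2c(Nc3ccc(F)c(Cl)c3)ncnc2cc1O[C@H]1CCOC1` has not yet been measured. It differs from compound 1 by ethynyl in place of (dimethylamino)methyl on a saturated chain carbon bound to an amide-type nitrogen. As in both measured steps away from compound 1, the dimethylamino group of compound 1 is gone, and here nothing carrying a hydrogen-bond acceptor takes its place. Those two steps are the ones that bear on this change, and both were modest losses of inhibition: a 5.1-fold higher number from compound 1 to compound 2 (0.71 log units; beyond the scatter), and a 3.8-fold higher number from compound 1 to compound 3 (0.58 log units; beyond the scatter). A loss of similar size is therefore expected for compound 4, namely a 4.3-fold higher number from compound 1 to compound 4 (0.64 log units; beyond the scatter), in the direction of a weaker inhibitor, clearly beyond the scatter of this assay. Compound 4 is thus estimated to give 3500 nM in this assay, with a range from 1500 nM to 9000 nM.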

Compound 4, half-maximal inhibitory concentration: 3730 nM
Beside the measured number, compound 4's estimate is 1.1-fold (0.03 log units) below it; the measured number falls inside the stated range.
By their numbers in this assay, from the lowest: compound 1; then compounds 3, 4 and 2 (each within the scatter of the next).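

In this assay, replacing the 2-(dimethylamino)ethyl chain of compound 1 with propargyl gives a 4.6-fold higher number from compound 1 to compound 4 (0.67 log units; beyond the scatter) and so adds a third, quite different replacement at this position that raises the number. The new value cannot be told apart from those of the other two replacements, with a 1.2-fold higher number from compound 3 to compound 4 (0.09 log units; within the scatter) and a 1.1-fold lower number from compound 2 to compound 4 (0.04 log units; within the scatter) as the printed steps, so only compound 1 stands apart from this shared level. That level holds for the methoxy-bearing chain of compound 2 and equally for the propargyl group, which has no hydrogen-bond acceptor, but no measurement here explains the pattern.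

The compounds shown leave open whether the lower number of compound 1 depends on the dimethylamino group itself or would also appear with another amine, such as a pyrrolidine or morpholine at the chain end. They also leave open how the number responds to chain length, as a 3-(dimethylamino)propyl chain would test, and whether a carboxylic acid at the same place would stay at the shared level.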